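Changing the aryl group on a compound at the assay limit

A few compounds are considered here, and "the series" means these few. Any claim that something is new, unique, unknown or untested is made for them only; others in the source may bear on it.

Measured results in a functional assay on M21 cells (Homo sapiens) for antiproliferative activity, read by sulforhodamine B assay, with a stated time of 48 h (on this read-out lower numbers stand for stronger inhibition and higher numbers for weaker inhibition), are these
compound 1 `COc1ccccc1OS(=O)(=O)c1ccc(N2CCN(C)C2=O)cc1` gives 21000 nM
compound 2 `CN1CCN(c2ccc(S(=O)(=O)Oc3cccc(I)c3)cc2)C1=O` gives 400 nM
compound 3 `CCN1CCN(c2ccc(S(=O)(=O)Oc3ccccc3OC)cc2)C1=O` gives > 100000 nM (a limit, not a number)

In this assay compound 3 sits at > 100000 nM (a limit of the assay). Its closest measured relation is an at least 4.7-fold higher number from compound 1 to compound 3 (0.67 log units; beyond the scatter) (methyl in place of hydrogen on a saturated chain carbon bound to an amide-type nitrogen in a ring).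

Compound 4 `CCN1CCN(c2ccc(S(=O)(=O)Oc3cccc(Cl)c3)cc2)C1=O` keeps that ethyl-bearing structure and brings one change: 3-chlorophenyl in place of 2-methoxyphenyl on an oxygen. The nearest guide is a 53-fold lower number from compound 1 to compound 2 (1.72 log units; beyond the scatter) (3-iodophenyl in place of 2-methoxyphenyl on an oxygen), a large step beyond the scatter. That step involved iodine rather than chlorine and began from a measured number, so it transfers only roughly. Within the data shown here, a large fall is still expected, because a 53-fold lower number from compound 1 to compound 2 (1.72 log units; beyond the scatter) (the only measured change of this aryl group) points that way. The expected size is an estimate: an at least 40-fold lower number from compound 3 to compound 4 (1.60 log units; beyond the scatter) (toward stronger inhibition). Compound 4 is expected in this assay at 2500 nM (estimated range 500 nM to 12000 nM).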

Compound 4, half-maximal inhibitory concentration: 3900 nM
Compound 4: the middle estimate sits 1.6-fold (0.19 log units) below what was measured, within the range that was stated.
By their numbers in this assay, from the lowest: compound 2; then compound 4; then compound 1. At a limit, above all of these: compound 3.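

In this assay, 3-chlorophenyl in place of 2-methoxyphenyl on the oxygen bound to the sulfonyl sulfur gives an at least 25-fold lower number from compound 3 to compound 4 (1.40 log units; beyond the scatter), so a change at this place alone brings an ethyl-bearing compound down from the assay limit. The earlier step, a 53-fold lower number from compound 1 to compound 2 (1.72 log units; beyond the scatter), came from the methyl-bearing pair with 3-iodophenyl, so a large fall on leaving 2-methoxyphenyl now appears with both the methyl and the ethyl compounds, and with both iodine and chlorine. Compound 3 stands at a limit, not a number, so the full size of the new step stays unknown: the limit of > 100000 nM in this assay, at which 1 of the 4 values shown sits.

Compound 2 and compound 4 differ in two places, so the effects of iodine and chlorine cannot be separated here. Also open, going by these compounds, is whether an amine or a carboxylic acid on this aryl ring, or a longer chain in place of the ethyl, would keep the gain.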